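Aryl replacement on the fused core of compound 1

This account rests on a few compounds, and the source may have more. Where it says the series, first, only, none or still open, it means among the compounds named here.

Measured compounds:
compound 1 `COc1cc(-c2ccnc3cc(-c4ccc(C)c(C)c4)nn23)cc(OC)c1OC` — 26 nM
compound 2 `COc1cc(-c2ccnc3cc(-c4ccccc4)nn23)cc(OC)c1OC` — 254 nM

In a functional assay on MCF7 cells (Homo sapiens) for inhibition, read by CCK-8 assay, with a stated time of 48 h (a higher number here means a weaker inhibitor, a lower number a stronger inhibitor), compound 1 gives 26 nM, the lowest of the two numbers; compound 2 gives 254 nM. For the measured compounds named here, the single step between them, a 9.8-fold higher number from compound 1 to compound 2 (0.99 log units; beyond the scatter), is the only one that bears on the change considered here.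

Compound 3 `COc1ccc(-c2cc3nccc(-c4cc(OC)c(OC)c(OC)c4)n3n2)cc1F` is not yet measured. Relative to compound 1 it shows (3-fluoro-4-methoxyphenyl in place of 3,4-dimethylphenyl on an aromatic carbon). Compound 3 keeps a substituted phenyl, 3-fluoro-4-methoxyphenyl, where compound 2 carries bare phenyl, so the weakening seen in a 9.8-fold higher number from compound 1 to compound 2 (0.99 log units; beyond the scatter) is expected only in part. The step of a 2.1-fold higher number from compound 1 to compound 3 (0.33 log units; beyond the scatter) is estimated as a modest weakening, possibly within the scatter. Compound 3 is expected at 55 nM, within 18 nM to 180 nM.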

Compound 3, half-maximal inhibitory concentration: 183 nM
For compound 3 the middle estimate is 3.3-fold (0.52 log units) below the measured one; measured number above the stated range.
By their numbers in this assay, from the lowest: compound 1; then compounds 3 and 2 (each within the scatter of the next).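

In this assay the change to 3-fluoro-4-methoxyphenyl at this position gives a 7.0-fold higher number from compound 1 to compound 3 (0.85 log units; beyond the scatter) and does not hold the level of 3,4-dimethylphenyl. Against bare phenyl, the same group gives a 1.4-fold lower number from compound 2 to compound 3 (0.14 log units; within the scatter) and so offers no separation from the unsubstituted ring, which shows that a substituent on this phenyl is not enough by itself to match compound 1. Nothing available accounts for the difference between these two substituted rings. Still open, as far as these compounds go, is how a phenyl with a single methyl, or with an amine or a carboxylic acid, would behave at this position.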